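Isopropyl to cyclohexylmethyl: working notes on compound 3

This account rests on a few compounds, and the source may have more. Where it says the series, first, only, none or still open, it means among the compounds named here.

For the measured compounds named here, in a functional assay on THP-1 cells (Homo sapiens) for inhibition, read by luminescence, with a stated time of 72 h, tested at 5 uM (a higher number here means more inhibition of growth at the concentration tested, a lower number less inhibition of growth), compound 2 (`COc1cc(O)c(C(=O)OC(C)C)c(/C=C/CN2C(=O)C=CC2=O)c1`) gives 41.8%, the higher of the two numbers so far. Compound 1 (`C=CS(=O)(=O)NC/C=C/c1cc(OC)cc(O)c1C(=O)OCC1CCCCC1`) gives 26.5%, which is lower by more than the usual scatter.

The next compound, compound 3 (`COc1cc(O)c(C(=O)OCC2CCCCC2)c(/C=C/CN2C(=O)C=CC2=O)c1`), carries cyclohexylmethyl in place of isopropyl on an oxygen next to a carbonyl group. Going by the values given here, no measured pair of compounds isolates a change at this place, so the series offers no direct guide to its size. With so little to go on, only a small upward move is expected in this assay, and the estimated step of a number 4.2 percentage points higher from compound 2 to compound 3 (within the scatter) stays within the usual scatter. The uncertainty remains wide in both directions. For compound 3 the expected value is 46%, with an estimated range of 28% to 66%.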

Compound 3, percent growth inhibition at one concentration: 5.9%
Estimate against measurement, compound 3: 40.1 percentage points above; measured number below the stated range.
By their numbers in this assay, from the lowest: compound 3; then compound 1; then compound 2.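

In this assay the ester position proves far from neutral: cyclohexylmethyl in place of isopropyl on an oxygen next to a carbonyl group gives a number 35.9 percentage points lower from compound 2 to compound 3 (beyond the scatter) and so costs most of the growth inhibition seen with isopropyl. With cyclohexylmethyl held constant, the group bearing a five-membered non-aromatic ring, in place of the open-chain group bearing sulfur, gives a number 20.6 percentage points lower from compound 1 to compound 3 (beyond the scatter) and so does not by itself secure inhibition at the concentration tested. Nothing available on these compounds accounts for either step.

The compounds shown leave open whether the loss follows the ring itself or the added carbon count, which a straight hexyl chain or a methyl ester would help to separate. On these data alone, whether the sulfur-bearing group behaves the same way alongside isopropyl also remains open.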